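Swapping a side chain on a urea-linked helicase inhibitor

The source may report more compounds than this note shows. Statements on the series, on what has been measured and on what is new or still open speak of the compounds shown alone.

Of the compounds shown here, three built on the same urea core have been measured in an assay on isolated protein for inhibition of ATP-dependent RNA helicase DDX3X (Homo sapiens), read by FRET, with stated times of 30 s and 40 min; on this read-out lower numbers stand for stronger inhibition and higher numbers for weaker inhibition. Compound 1 `Cc1ccccc1NC(=O)Nc1ccc(-n2cc(CCO)nn2)cc1` gives 13000 nM. Compound 2 `CCCCc1cn(-c2ccc(NC(=O)Nc3cc(OCOC)ccc3C)cc2)nn1` gives 820 nM, and compound 3 `CCOCc1cn(-c2ccc(NC(=O)Nc3cc(C(C)C)ccc3C)cc2)nn1` gives 1510 nM. Compound 2 has the lowest number of the three, but its gap to compound 3 lies within the usual scatter, so those two cannot be told apart; only the gap to compound 1 is clearly beyond the scatter.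

Compound 4 `CCCCc1cn(-c2ccc(NC(=O)Nc3cc(CCC(C)=O)ccc3C)cc2)nn1` has not yet been measured. It differs from compound 2 in one place: 2-acetylethyl in place of methoxymethoxy on an aromatic carbon. Among the measured compounds shown here, no measured pair shows this particular exchange, so nothing in the data tells how large its effect is or in which direction it runs. The expectation is therefore a step of modest size, no larger than the scatter, and compound 4 is estimated at 1200 nM in this assay, with a plausible range from 450 nM to 3200 nM. Expressed as a step, this estimate means a 1.5-fold higher number from compound 2 to compound 4 (0.17 log units; within the scatter).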

Compound 4, half-maximal inhibitory concentration: 2490 nM
Estimate against measurement, compound 4: 2.1-fold (0.32 log units) below, within the range that was stated.
By their numbers in this assay, from the lowest: compounds 2, 3 and 4 (each within the scatter of the next, the first and the last beyond it); then compound 1.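

Among the compounds shown here, this exchange is the first single change that can be read directly: on the aromatic carbon para to a methyl group, 2-acetylethyl in place of methoxymethoxy gives a 3.0-fold higher number from compound 2 to compound 4 (0.48 log units; beyond the scatter) in this assay. The step is modest, but it shows that this position is not indifferent to which chain it carries, even though neither group has a ring or a net charge. No measurement here explains why the number rises.

Going by these compounds, it remains open whether an amine, a carboxylic acid or a longer chain at this position would bring the number closer to that of compound 2 or push it further away. Also open, on these data alone, is whether the same exchange would give a step of similar size with a different side chain elsewhere on the shared core.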